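Moving the methoxy group on a shorter-linker analogue

The source may hold more compounds than are shown below. What is called first, only, known or untested is meant among the compounds shown, and "the series" means these compounds.

Compound 3 `COc1ccccc1/C=C/C(=O)/C=C/c1ccc(OCc2cn(CCOc3cc(=O)oc4ccccc34)nn2)c(OC)c1` and compound 2 `COc1ccccc1/C=C/C(=O)/C=C/c1ccc(OCc2cn(CCCCCOc3cc(=O)oc4ccccc34)nn2)c(OC)c1` share much of their skeleton, but the difference between the two cores is not broken down here. In a functional assay on THP-1 cells (Homo sapiens) for inhibition, read by sulforhodamine B assay, with a stated time of 48 h, tested at 50 uM (on this read-out higher numbers stand for more inhibition of growth at the one concentration tested and lower numbers for less inhibition of growth), compound 3 gives 75%, whereas compound 2 gives 37%. Compound 1 `COc1ccc(/C=C/C(=O)/C=C/c2ccc(OCc3cn(CCCCCOc4cc(=O)oc5ccccc45)nn3)c(OC)c2)cc1` gives 39%. Compound 1 arises from compound 2 by 4-methoxyphenyl in place of 2-methoxyphenyl on a double-bonded chain carbon bound to a double-bonded chain carbon, a change that produced a number 2 percentage points higher from compound 2 to compound 1 (within the scatter). Compound 4 `COc1ccc(/C=C/C(=O)/C=C/c2ccc(OCc3cn(CCOc4cc(=O)oc5ccccc45)nn3)c(OC)c2)cc1` has not been measured; it arises from compound 3 by the same change, (4-methoxyphenyl in place of 2-methoxyphenyl on a double-bonded chain carbon bound to a double-bonded chain carbon), at the same place. For compound 4 the expected step is a number 1 percentage points higher from compound 3 to compound 4 (within the scatter), which rests on the measured a number 2 percentage points higher from compound 2 to compound 1 (within the scatter). Compound 4 is therefore estimated to give about 76%, most likely between 62% and 88%.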

Compound 4, percent growth inhibition at one concentration: 78%
The estimate for compound 4 lay 2 percentage points below the measured number; low and high end bracket the measured number.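

Putting 4-methoxyphenyl in place of 2-methoxyphenyl on the shorter-linker core gives a small step in this assay, a number 3 percentage points higher from compound 3 to compound 4 (within the scatter). Set beside the same change on the longer-linker core, the step carries over at a similar size: the same change on two cores in this assay, a number 2 percentage points higher (within the scatter) from compound 2 to compound 1 and a number 3 percentage points higher (within the scatter) from compound 3 to compound 4, 1 percentage points apart, within the scatter of two such steps. This shows that the swap leaves the read-out within the scatter on these two cores, but two pairs at the one concentration tested do not show that it would behave the same way on any other core.

On these data alone, it remains open whether a 4-hydroxyphenyl or 4-chlorophenyl group in the same place would shift the number. As far as these compounds go, a longer chain carrying a terminal amine is likewise open.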